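Fluoro to Bromo: Estimating the Next Compound

The source may hold more compounds than are shown below. What is called first, only, known or untested is meant among the compounds shown, and "the series" means these compounds.

Measured so far:
- Compound 1, `c1ccc(COc2nc3ccccc3s2)cc1`: 68.8%
- Compound 2, `Fc1cccc(COc2nc3ccccc3s2)c1`: 86.8%
- Compound 3, `Brc1ccc(OCCOc2nc3ccccc3s2)cc1`: 94.6%

All three were tested in a functional assay on the whole organism with Mus musculus as the target, with a stated time of 1 h, at a dose of 100 mg/kg by the intraperitoneal route; on this read-out higher numbers stand for more inhibition at the one dose given (going by the name of the read-out) and lower numbers for less inhibition. Compound 2 stands clearly above compound 1: the step of a number 18 percentage points higher from compound 1 to compound 2 (beyond the scatter) is beyond the scatter. Compound 3 gives 94.6%, which lies within the scatter of compound 2, so those two cannot be ranked against each other.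

Compound 4, `Brc1cccc(COc2nc3ccccc3s2)c1`, has not yet been measured. It differs from compound 2 in one place: bromo in place of fluoro on an aromatic carbon. Among the compounds with values here, no measured step exchanges one halogen for another. Within the data shown here, the only halogen step known, a number 18 percentage points higher from compound 1 to compound 2 (beyond the scatter), added a halogen where there was none, so it bears on the change only loosely. Compound 3 carries a bromo group on a ring attached through a longer chain and gives 94.6%, a high number, so a bromo-bearing compound scoring well is at least not unusual here. The expected step is a number 1.8 percentage points lower from compound 2 to compound 4 (within the scatter), none beyond the scatter. Compound 4 is therefore estimated at 85%, with a range from 65% to 98%.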

Compound 4, a percentage reported as inhibition, in the whole organism at one dose (the size of the read-out at that dose, not a potency): 77.6%
Estimate against measurement, compound 4: 7.4 percentage points above, within the range that was stated.
By their numbers in this assay, from the lowest: compounds 1, 4, 2 and 3 (each within the scatter of the next, the first and the last beyond it).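

At this position, on an aromatic carbon meta to a large group, the exchange of one halogen for the other gives a number 9.2 percentage points lower from compound 2 to compound 4 (within the scatter) in this assay and so leaves fluoro and bromo unseparated. Bromo in place of hydrogen gives a number 8.8 percentage points higher from compound 1 to compound 4 (within the scatter) and stays inside the scatter, whereas fluoro in place of hydrogen gives a number 18 percentage points higher from compound 1 to compound 2 (beyond the scatter) and goes beyond it, so compound 4 cannot be separated from either compound 1 or compound 2, though those two are separated from each other. No measurement at hand offers an explanation for these results.

The compounds shown leave open how chloro, methoxy or an amine would read at this same place. They also leave open whether fluoro and bromo would stay unseparated elsewhere on the ring.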